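This account rests on a few compounds, and the source may have more. Where it says the series, first, only, none or still open, it means among the compounds named here.

In a functional assay on MCF7 cells (Homo sapiens) for inhibition, read by sulforhodamine B assay, with a stated time of 72 h (on this read-out lower numbers stand for stronger inhibition of growth and higher numbers for weaker inhibition of growth), compound 3 `NC(=O)/C=C/c1ccncc1-c1ccc2ccccc2c1` gives > 10000 nM, which is a limit and not a number. Compound 4 `CN(C)C(=O)/C=C/c1ccncc1-c1ccc2ccccc2c1` differs from it by dimethylamino in place of amino on a carbonyl carbon, with dimethylamino in place of amino on a carbonyl carbon. Among the compounds with values here, two measured steps bear on this change. The one on the same carbonyl carbon is a step that the two limits leave unreadable from compound 1 to compound 3, and it links compound 1 `CN1CCN(C(=O)/C=C/c2ccncc2-c2ccc3ccccc3c2)CC1`, which holds 4-methylpiperazin-1-yl there. Compound 1 gives > 10000 nM, also a limit. The other is a step that the two limits leave unreadable from compound 2 to compound 3, and it involves compound 2 `NNC(=O)CCc1ccncc1-c1ccc2ccccc2c1`. Compound 2 gives > 10000 nM, again a limit. Within the data shown here, neither step has a readable size, and the series so far shows only (the limit of > 10000 nM in this assay, at which 3 of the 3 values shown sit). With compound 1 giving > 10000 nM despite its larger group on that carbon, no step beyond the scatter is expected in this assay, and no direction can be assigned. The expected outcome is a step that the limit leaves unreadable from compound 3 to compound 4. For compound 4 the estimated value is 15000 nM, with an expected range from 6000 nM to 40000 nM.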

Compound 4, concentration for 50% growth inhibition: 8190 nM
Compound 4: middle estimate off by 1.8-fold (0.26 log units), on the high side; low and high end bracket the measured number.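

In this assay, within the data shown here, compound 4 is the first compound here to give a number rather than a limit, so a change on this carbonyl carbon now yields a value that can be placed, while the other compounds share one ceiling: the limit of > 10000 nM in this assay, at which 3 of the 4 values shown sit. With dimethylamino in place of amino, the result is an at least 1.2-fold lower number from compound 3 to compound 4 (0.08 log units; that floor lies within the scatter). The other two comparisons give an at least 1.2-fold lower number from compound 2 to compound 4 (0.08 log units; that floor lies within the scatter) and an at least 1.2-fold lower number from compound 1 to compound 4 (0.08 log units; that floor lies within the scatter), so none of the three establishes a change beyond the scatter.

On these data alone, how large the step from amino to dimethylamino really is stays open, as compound 3 is held at a limit. Also open, as far as these compounds go, is what a diethylamino group, a pyrrolidine or a carboxylic acid on the same carbonyl carbon would give.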